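Chloro for methyl on an unresponsive chromone series

The source may hold more compounds than are shown below. What is called first, only, known or untested is meant among the compounds shown, and "the series" means these compounds.

Compound 1 `O=c1cc(CSc2nc3ccccc3s2)oc2ccc(Cl)cc12`: in a functional assay on HeLa cells (Homo sapiens) for cytotoxicity, read by MTT assay, with a stated time of 72 h (a higher number here means a weaker inhibitor, a lower number a stronger inhibitor), compound 1 gives > 25000 nM, which is a limit of the assay.
Compound 2 `Cc1cc(C)n2nc(SCc3nnc(SCc4coc5ccccc5c4=O)n3N)nc2n1`: in this assay compound 2 gives > 25000 nM, again a limit of the assay.
Compound 3 `Cc1ccc2oc(CSc3nnc(N)s3)cc(=O)c2c1`: in this assay compound 3 gives > 25000 nM, also a limit of the assay.

Among the compounds with values here, compound 3 therefore stands nowhere in particular among the three: every value shown is the same limit, and no compound has a number that can be set against another. The only fixed point in these data is the limit of > 25000 nM in this assay, at which 3 of the 3 values shown sit, so nothing here separates any compound from the rest.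

Compound 4 `Nc1nnc(SCc2cc(=O)c3cc(Cl)ccc3o2)s1` is the next compound to be measured. It differs from compound 3 in one place: chloro in place of methyl on an aromatic carbon. The exchange happens on an aromatic carbon of a six-membered aromatic ring of carbon only, part of a fused system of two rings, and the rest of the molecule is kept.

Within the data shown here, with no measured step to go by, the expectation for compound 4 is that the step that the limit leaves unreadable from compound 3 to compound 4 stays within the usual scatter, which for a limit means that compound 4 is again expected to sit at or beyond that limit. The estimate for compound 4 in this assay is 30000 nM, with a range from 12000 nM to 80000 nM.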

Compound 4, half-maximal inhibitory concentration: > 25000 nM
Compound 4 ended at the assay's limit; the forecaster's own chance of this, stated with the estimate: 80%; the middle value is on the limit's open side.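

Within the data shown here, compound 3 and compound 4 both rest at a limit of the assay, so the exchange of methyl for chloro gives no step that can be read in this assay. The compounds shown leave open which change, if any, would bring a measurable value, as all of them share a single point: the limit of > 25000 nM in this assay, at which 4 of the 4 values shown sit.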